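Notes on the chloroalkanoyl amide variation

The source may report more compounds than this note shows. Statements on the series, on what has been measured and on what is new or still open speak of the compounds shown alone.

Of the compounds shown here, three of the shared core have been measured in a functional assay on A875 cells (Homo sapiens) for antiproliferative activity, read by MTT assay, with a stated time of 48 h; a lower number here means a stronger inhibitor, a higher number a weaker inhibitor. Compound 1 `O=C(CSc1nnc(NC(=O)c2c(Cl)cccc2Cl)s1)Nc1ccc(Br)cn1` gives 18600 nM. Compound 2 `O=C(CSc1nnc(NC(=O)CCl)s1)Nc1ccc(Cl)cn1` gives 8600 nM. Compound 3 `O=C(CSc1nnc(NC(=O)CCl)s1)Nc1ccc(Br)cn1` gives 13900 nM. Compound 3 thus stands second highest of the three numbers; its nearest neighbour is compound 1, as a 1.3-fold lower number from compound 1 to compound 3 (0.13 log units; within the scatter) shows, and its furthest is compound 2, as a 1.6-fold higher number from compound 2 to compound 3 (0.21 log units; within the scatter) shows, so all three lie within the scatter of one another and no order among them can be claimed.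

Compound 4 `O=C(CSc1nnc(NC(=O)CCCl)s1)Nc1ccc(Br)cn1` is the next member. Against compound 3 the change is chloromethyl in place of chloro on a saturated chain carbon bound to a carbonyl carbon. Of the measured steps, the one that touches the same carbonyl carbon is a 1.3-fold lower number from compound 1 to compound 3 (0.13 log units; within the scatter), where a far larger swap at that carbonyl, chloromethyl for 2,6-dichlorophenyl, moved the number only within the scatter. The step of a 1.6-fold higher number from compound 2 to compound 3 (0.21 log units; within the scatter) changes a different part of the molecule and bears on the present change only as a further sign of how little the series moves. A change of the present small size is therefore expected to give no step beyond the scatter in this assay, in either direction, so a 1.1-fold lower number from compound 3 to compound 4 (0.03 log units; within the scatter) is the estimated size. Compound 4 is accordingly expected to give 13000 nM, with a range from 6000 nM to 30000 nM.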

Compound 4, half-maximal inhibitory concentration: 430 nM
Estimate against measurement, compound 4: 30-fold (1.48 log units) above; measured number outside the range, below it.
By their numbers in this assay, from the lowest: compound 4; then compounds 2, 3 and 1 (each within the scatter of the next, the first and the last beyond it).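

In this assay the carbonyl substituent proves to be a position that can move the number strongly: the small change from chloromethyl to 2-chloroethyl gives a 32-fold lower number from compound 3 to compound 4 (1.51 log units; beyond the scatter) and so lies well beyond the scatter. The earlier swap at the same carbonyl carbon, a 1.3-fold lower number from compound 1 to compound 3 (0.13 log units; within the scatter) with chloromethyl in place of 2,6-dichlorophenyl, stayed within the scatter, so the flat picture from compounds 1 and 3 did not hold for this position as a whole; the replacement of 2,6-dichlorophenyl by 2-chloroethyl gives a 43-fold lower number from compound 1 to compound 4 (1.64 log units; beyond the scatter) and confirms that the gain goes with this one group rather than with any small chloroalkyl group. Nothing among the available data accounts for the size of this jump.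

The compounds shown leave open whether the gain depends on the terminal chlorine or on the chain itself, which a plain ethyl group, a terminal amine or a hydroxyl group in place of that chlorine would test, and whether a longer chain such as 3-chloropropyl continues or reverses it. They also leave open whether 2-chloroethyl gives a similar step with chloro in place of bromo on the aromatic carbon, as in compound 2.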